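The source may report more compounds than this note shows. Statements on the series, on what has been measured and on what is new or still open speak of the compounds shown alone.

Series read-out: an assay on isolated protein for inhibition of leukotriene B4 receptor 1 (Homo sapiens), tested at 10 uM; on this read-out lower numbers stand for less inhibition and higher numbers for more inhibition at the one concentration tested (going by the name of the read-out).

Measured so far:
compound 1 `CCCCc1cc(C(C)=O)c(O)cc1OCCCCC#N`: 41%
compound 2 `COCc1cc(C(C)=O)c(O)cc1OCCCCCCC#N`: 47%
compound 3 `CCc1cc(C(C)=O)c(O)cc1OCCCC(C)(C)C(=O)O`: 89%

Compound 3 stands highest of the three numbers. Compound 2 lies nearest to it, a number lower by a margin beyond the scatter; compound 1 lies furthest, also beyond the scatter. Both lower compounds carry a nitrile at the chain end where compound 3 carries the carboxy group.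

Compound 4 `CCc1cc(C(C)=O)c(O)cc1OCCCCCCS(C)(=O)=O` has not yet been measured in this assay. It differs from compound 3 in one place: 3-(methylsulfonyl)propyl in place of 1-carboxy-1-methylethyl on a saturated chain carbon, three bonds along the chain from an oxygen on an aromatic ring. One hydrogen-bond donor leaves and none enters. Going by the values given here, no step between measured compounds is available for this kind of change, so the expectation rests on the gap between compound 3 and the two nitrile compounds. Compound 4 is expected to fall from compound 3 by a number 39 percentage points lower from compound 3 to compound 4 (beyond the scatter), a step beyond the scatter. In this assay compound 4 is estimated at 50%, within a range of 25% to 75%.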

Compound 4, a percentage reported as inhibition, at one concentration (the size of the read-out at that concentration, not a potency): 99%
The estimate for compound 4 lay 49 percentage points below the measured number; measured number outside the range, above it.
By their numbers in this assay, from the lowest: compounds 1 and 2 (each within the scatter of the next); then compounds 3 and 4 (each within the scatter of the next).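

In this assay, 3-(methylsulfonyl)propyl in place of 1-carboxy-1-methylethyl on this saturated chain carbon gives a number 10 percentage points higher from compound 3 to compound 4 (within the scatter). For this pair, the carboxy group and its hydrogen-bond donor are therefore not required to keep the read-out at this level, and a chain end with a sulfone serves equally well. No available evidence accounts for this result. Open, from the compounds shown here alone, is whether a sulfonamide or an amine at the chain end would give a similar read-out. Also open, going by these compounds, is whether a shorter chain carrying the methylsulfonyl group would do so.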